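A few compounds are considered here, and "the series" means these few. Any claim that something is new, unique, unknown or untested is made for them only; others in the source may bear on it.

Measured compounds: compound 1 `Cc1ccnc2nc(-c3cccc4ccccc34)cc(O)c12`; compound 2 `Cc1cc(C)c2c(O)cc(-c3cccc4ccccc34)nc2n1`; compound 3 `Cc1ccc2c(O)cc(-c3ccc4ccccc4c3)nc2n1`.

In a functional assay on SK-MEL-5 cells (Homo sapiens) for antiproliferative activity (a lower number here means a stronger inhibitor of growth, a higher number a weaker inhibitor of growth), compound 1 reports < 10 nM, which is a limit of the assay and not a number, at the limit of < 10 nM in this assay, at which 1 of the 3 values shown sits. In this assay compound 2 gives 468 nM, and compound 3 gives 3310 nM. The step of an at least 46-fold higher number from compound 1 to compound 2 (1.67 log units; beyond the scatter) accompanies (methyl in place of hydrogen on an aromatic carbon). Compound 1 and compound 3 hold the same atoms joined differently; the difference between the two cores is not broken down here. Compound 4 `Cc1cc(C)c2c(O)cc(-c3ccc4ccccc4c3)nc2n1` is not yet measured. It differs from compound 3 by methyl in place of hydrogen on an aromatic carbon, the same kind of change as from compound 1 to compound 2, though the place is not identical: here ortho to a fused ring and opposite the ring nitrogen, there next to the ring nitrogen and para to a fused ring. Resting on an at least 46-fold higher number from compound 1 to compound 2 (1.67 log units; beyond the scatter), compound 4 is expected to show a weakening step in this assay of a 3.6-fold higher number from compound 3 to compound 4 (0.56 log units; beyond the scatter). The estimate for compound 4 in this assay is 12000 nM, between 2500 nM and 50000 nM.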

Compound 4, concentration for 50% growth inhibition: 2190 nM
Estimate against measurement, compound 4: 5.5-fold (0.74 log units) above, and the stated range ends above it.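

In this assay, methyl in place of hydrogen on an aromatic carbon gives a 1.5-fold lower number from compound 3 to compound 4 (0.18 log units; within the scatter), so on the core of compound 3 this change leaves the number within the scatter. The change does not carry over in size from one core to the other: the same change on two cores in this assay, an at least 46-fold higher number (1.67 log units; beyond the scatter) from compound 1 to compound 2 and a 1.5-fold lower number (0.18 log units; within the scatter) from compound 3 to compound 4, at least 70-fold (1.84 log units) apart, beyond the scatter of two such steps. These two pairs do not show why the steps differ, and compound 1 is reported only as a limit and not a number, so the true size of the earlier step remains unknown: the limit of < 10 nM in this assay, at which 1 of the 4 values shown sits.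

The compounds shown leave open how either core responds to an ethyl group, a methoxy group or an amine in place of methyl. They also leave open whether a third core would follow either step.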